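The compounds below may be only part of what the source reports. "The series", "measured", "known", "first", "only" and "open" are said of these compounds alone.

Of the compounds shown here, two share one core and have been tested in an assay on isolated protein for inhibition of protein deacetylase HDAC6 (Homo sapiens), read by fluorescence, with stated times of 3 h and 60 min; a higher number here means a weaker inhibitor, a lower number a stronger inhibitor. Compound 1 `Nc1ccccc1NC(=O)c1ccc(CNC2=NC(=O)C(c3ccccc3)N2)cc1` carries a phenyl on a saturated ring carbon. In this assay compound 1 gives > 20000 nM, which is a limit of the assay and not a number. Compound 2 `Nc1ccccc1NC(=O)c1ccc(CNC2=NC(=O)C(Cc3c[nH]c4ccccc34)N2)cc1` carries a (1H-indol-3-yl)methyl on that saturated ring carbon instead. In this assay compound 2 gives > 20000 nM, which is again a limit of the assay. That step reads a step that the two limits leave unreadable from compound 1 to compound 2. Compound 2 thus stands at the assay limit, the point where both values shown sit (the limit of > 20000 nM in this assay, at which 2 of the 2 values shown sit).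

Compound 3 `CC(C)(C)OC(=O)N1C(NCc2ccc(C(=O)Nc3ccccc3N)cc2)=NC(=O)C1Cc1c[nH]c2ccccc12` differs from compound 2 by tert-butoxycarbonyl in place of hydrogen on an amine nitrogen in a ring. For the measured compounds named here, only one measured step exists, and it is unreadable, so no step size can be taken from it. The change from compound 2 to compound 3 also touches a different place than that step does. The expectation for compound 3 is therefore that it also sits at the limit, with the estimated step that the limit leaves unreadable from compound 2 to compound 3 meaning no readable change in this assay. Compound 3 is estimated at 25000 nM, between 5000 nM and 100000 nM.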

Compound 3, half-maximal inhibitory concentration: > 20000 nM
Compound 3: no number, only a limit; the forecaster's own chance of this, stated with the estimate: 75%; the middle value lies beyond the limit too.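

Compound 3 also gives only a limit of the assay and not a number, so no step can be read between compound 2 and compound 3: the limit of > 20000 nM in this assay, at which 3 of the 3 values shown sit.

The compounds shown leave open how strongly any of them inhibits in this assay, and whether tert-butoxycarbonyl in place of hydrogen changes that at all.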